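The compounds below may be only part of what the source reports. "The series", "measured", "known", "first", "only" and "open" are said of these compounds alone.

In an assay on isolated protein for inhibition of polyamine deacetylase HDAC10 (Homo sapiens) (a lower number here means a stronger inhibitor, a higher number a weaker inhibitor), compound 1 `COc1ccc(C(=O)c2ccc3c(ccn3Cc3ccc(C(=O)NO)cc3)c2)cc1OC` gives 18900 nM, while compound 2 `COc1ccc(C(=O)c2ccc3c(ccn3Cc3ccc(C(=O)NO)cc3)c2)cc1` gives 59800 nM. Compound 3 `O=C(NO)c1ccc(Cn2ccc3cc(C(=O)c4ccc(Cl)cc4)ccc32)cc1` reaches only a limit in this assay, > 100000 nM, a floor rather than a measured number, which is the limit of > 100000 nM in this assay, at which 1 of the 3 values shown sits. The change from compound 3 to compound 4 `COc1cccc(C(=O)c2ccc3c(ccn3Cc3ccc(C(=O)NO)cc3)c2)c1` is 3-methoxyphenyl in place of 4-chlorophenyl on a carbonyl carbon. Going by the values given here, two measured steps bear on this: an at least 5.2-fold higher number from compound 1 to compound 3 (0.72 log units; beyond the scatter) and an at least 1.6-fold higher number from compound 2 to compound 3 (0.22 log units; that floor lies within the scatter), both showing weaker inhibition once a chloro replaces a methoxy, so putting a methoxy back is expected to move the other way. The step expected from compound 3 to compound 4 in this assay is an at least 1.6-fold lower number from compound 3 to compound 4 (0.22 log units; that floor lies within the scatter). Compound 4 is therefore estimated at about 60000 nM, within a range from 25000 nM to 150000 nM.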

Compound 4, half-maximal inhibitory concentration: 47900 nM
Compound 4: the middle estimate sits 1.3-fold (0.10 log units) above what was measured; low and high end bracket the measured number.
By their numbers in this assay, from the lowest: compound 1; then compounds 4 and 2 (each within the scatter of the next). At a limit, above all of these: compound 3.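

Compound 3 stands at a limit of the assay, so the step to its 3-methoxyphenyl counterpart (an at least 2.0-fold lower number from compound 3 to compound 4 (0.31 log units; beyond the scatter)) is only a floor, though this floor clears the scatter: the limit of > 100000 nM in this assay, at which 1 of the 4 values shown sits. With a single methoxy, 3-methoxyphenyl and 4-methoxyphenyl cannot be told apart here (a 1.2-fold lower number from compound 2 to compound 4 (0.10 log units; within the scatter)). Compound 1 carries both methoxy groups, and removing either one now weakens inhibition, the newly read case being a 2.5-fold higher number from compound 1 to compound 4 (0.40 log units; beyond the scatter).

Still open, going by these compounds, is whether a 3-chlorophenyl would behave like the 4-chlorophenyl of compound 3. Also open, on these data alone, is whether an aminophenyl or a hydroxyphenyl on the carbonyl carbon would approach compound 1.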